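Acetyl for fluoro on the pendant phenyl ring

The source may hold more compounds than are shown below. What is called first, only, known or untested is meant among the compounds shown, and "the series" means these compounds.

Compound 1 `Brc1cn2ccnc2c(-c2ccc3ncn(C4CCCCC4)c3c2)n1` and compound 2 `Fc1ccc(-c2cn3ccnc3c(-c3ccc4ncn(C5CCCCC5)c4c3)n2)cc1` share one core and differ in a single place. For the measured compounds named here, in a functional assay on HL-60 cells (Homo sapiens) for inhibition, read by sulforhodamine B assay, with a stated time of 48 h, tested at 10 uM (a higher number here means more inhibition at the concentration tested (going by the name of the read-out), a lower number less inhibition), compound 1 gives 18%, while compound 2 gives 2.03%, the lower of the two numbers measured so far; that change, 4-fluorophenyl in place of bromo on an aromatic carbon, produced a number 16 percentage points lower from compound 1 to compound 2 (beyond the scatter). Compound 3 `CC(=O)c1ccc(-c2cn3ccnc3c(-c3ccc4ncn(C5CCCCC5)c4c3)n2)cc1` keeps the phenyl ring of compound 2 and alters only its substituent: acetyl in place of fluoro on an aromatic carbon. Going by the values given here, no measured step concerns a change on that phenyl ring; the single step recorded replaced bromo on the core with the whole ring, so it gives no direct guidance here. With nothing pointing in either direction, the step expected in this assay is a number 6 percentage points higher from compound 2 to compound 3 (within the scatter), within the usual scatter. Compound 3 is therefore estimated at 8%, with a range from -8% to 30%.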

Compound 3, a percentage reported as inhibition, at one concentration (the size of the read-out at that concentration, not a potency): 2.65%
Compound 3: middle estimate off by 5.4 percentage points, on the high side; low and high end bracket the measured number.
By their numbers in this assay, from the lowest: compounds 2 and 3 (each within the scatter of the next); then compound 1.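

In this assay, putting acetyl in place of fluoro on the pendant phenyl ring, para to a large group, gives a number 0.6 percentage points higher from compound 2 to compound 3 (within the scatter) and so does not separate the two groups at this position. The comparison with the bromo compound also holds for the new ring, with a number 15.4 percentage points lower from compound 1 to compound 3 (beyond the scatter) matching in direction the step seen earlier for the 4-fluorophenyl group, so compound 2 and compound 3 both stand apart from compound 1 in the same way. No measurement is available to explain these readings.

On these data alone, whether an amine or a carboxylic acid at this place on the ring would shift the reading remains open. It is also unknown whether a longer chain in place of acetyl would bring the number back towards that of compound 1.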